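The compounds below may be only part of what the source reports. "The series", "measured", "known", "first", "only" and "open" are said of these compounds alone.

Measured in a functional assay on HeLa cells (Homo sapiens) for inhibition; on this read-out higher numbers stand for weaker inhibition of growth and lower numbers for stronger inhibition of growth:
- compound 1 `COC(=O)c1ccsc1NC(=O)[C@@H]1CCCN1`: > 250 ug/mL
- compound 2 `O=C(OC1CCCCC1)c1ccsc1NC(=O)[C@@H]1CCCN1`: 92.8 ug/mL
- compound 3 `O=C(OCC(Cl)(Cl)Cl)c1ccsc1NC(=O)[C@@H]1CCCN1`: > 250 ug/mL

Compound 3 stands at the limit of > 250 ug/mL in this assay, at which 2 of the 3 values shown sit, so its entry is a limit and not a number. Compound 1 sits at that same limit. Only compound 2 gives a true number.

Compound 4 `O=C(OCC(F)(F)F)c1ccsc1NC(=O)[C@@H]1CCCN1` has not yet been measured. It differs from compound 3 by trifluoromethyl in place of trichloromethyl on a saturated chain carbon bound to an oxygen next to a carbonyl group. Cut one bond further out, this reads 2,2,2-trichloroethyl to 2,2,2-trifluoroethyl.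

Going by the values given here, no measured step makes this exact swap. The nearest evidence comes from changing the group on the same oxygen. There, an at least 2.6-fold lower number from compound 1 to compound 2 (0.43 log units; beyond the scatter) and an at least 2.6-fold higher number from compound 2 to compound 3 (0.43 log units; beyond the scatter) are both at least modest, and both involve the cyclohexyl group of compound 2. By contrast, a step that the two limits leave unreadable from compound 1 to compound 3 cannot be read, since both ends are limits.

Compound 4 has no cyclohexyl group and stays closest to compound 3, so no change beyond the scatter is expected in this assay. The expected step is a number no higher from compound 3 to compound 4 (the limit leaves the size open), and a second report of only a limit is more likely than not. For compound 4 the estimated value is 250 ug/mL, with an expected range of 130 ug/mL to 400 ug/mL.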

Compound 4, concentration for 50% growth inhibition: 109 ug/mL
Compound 4: the middle estimate sits 2.3-fold (0.36 log units) above what was measured; the whole stated range lies above it.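

Trifluoromethyl in place of trichloromethyl on a saturated chain carbon bound to an oxygen next to a carbonyl group gives an at least 2.2-fold lower number from compound 3 to compound 4 (0.36 log units; beyond the scatter) in this assay, so exchanging only the halogen atoms at the end of this chain is enough to change the read-out beyond the scatter, which the earlier compounds could not show. Going by these compounds alone, a cyclohexyl group is also not the only group here that gives a true number, as 2,2,2-trifluoroethyl in place of cyclohexyl gives a 1.2-fold higher number from compound 2 to compound 4 (0.07 log units; within the scatter), and compounds 2 and 4 therefore cannot be told apart in this assay. Set against the methyl group of compound 1, there is an at least 2.2-fold lower number from compound 1 to compound 4 (0.36 log units; beyond the scatter), while compounds 1 and 3 themselves remain limits and not numbers: the limit of > 250 ug/mL in this assay, at which 2 of the 4 values shown sit.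

On these data alone, the step between compound 1 and compound 3 still cannot be read, so it remains unknown how those two groups compare. This single pair of halogen-bearing groups also leaves open how a 2,2,2-tribromoethyl group, a longer fluorinated chain such as 2,2,3,3,3-pentafluoropropyl, or a chain ending in an amine would behave on the same oxygen.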